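Aryl-triazole variation on a bicyclic lactam core

The compounds below may be only part of what the source reports. "The series", "measured", "known", "first", "only" and "open" are said of these compounds alone.

Measured compounds:
compound 1, `CC1(C)[C@H]2CC[C@]1(C)N(Cc1cn(-c3ccc(Cl)cc3)nn1)C(=O)C2`, in a functional assay on SGC-7901 cells (Homo sapiens) for inhibition, read by MTT assay, with a stated time of 24 h (on this read-out lower numbers stand for stronger inhibition and higher numbers for weaker inhibition), gives 410 nM
compound 2, `CC1(C)[C@H]2CC[C@]1(C)N(Cc1cn(-c3ccccc3)nn1)C(=O)C2`, in this assay gives 240 nM
compound 3, `CC1(C)[C@H]2CC[C@]1(C)N(Cc1cn(-c3ccccc3Br)nn1)C(=O)C2`, in this assay gives 500 nM

Compound 1 stands second highest of the three numbers in this assay, with compound 3 nearest and compound 2 furthest; all three values sit within the scatter of one another, so no order among them is claimed.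

Compound 4, `CC1(C)[C@H]2CC[C@]1(C)N(Cc1cn(-c3cccc(Br)c3)nn1)C(=O)C2`, is not yet measured. It differs from compound 1 as follows: 3-bromophenyl in place of 4-chlorophenyl on an aromatic nitrogen.

Among the compounds with values here, three measured steps bear on the change of the aryl group on the triazole nitrogen. Removing the chloro gave a 1.7-fold lower number from compound 1 to compound 2 (0.23 log units; within the scatter); exchanging the whole aryl gave a 1.2-fold higher number from compound 1 to compound 3 (0.09 log units; within the scatter); adding a bromo to the bare phenyl gave a 2.1-fold higher number from compound 2 to compound 3 (0.32 log units; beyond the scatter). Within the data shown here, the aryl substituent pattern thus moves the number only by small amounts, and only the step from compound 2 to compound 3 passes the scatter. For the move from compound 1 to compound 4 no step beyond the scatter is expected in this assay; compound 4 is expected near compound 1, a 1.1-fold higher number from compound 1 to compound 4 (0.04 log units; within the scatter).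

Compound 4 is therefore estimated at 450 nM in this assay, with a range of 220 nM to 950 nM.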

Compound 4, half-maximal inhibitory concentration: 120 nM
Beside the measured number, compound 4's estimate is 3.8-fold (0.57 log units) above it, outside the stated range (below it).
By their numbers in this assay, from the lowest: compounds 4, 2, 1 and 3 (each within the scatter of the next, the first and the last beyond it).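

In this assay, within the data shown here, the aryl group on the aromatic nitrogen proves more sensitive than the earlier compounds suggested: 3-bromophenyl in place of 2-bromophenyl gives a 4.2-fold lower number from compound 3 to compound 4 (0.62 log units; beyond the scatter) and 3-bromophenyl in place of 4-chlorophenyl gives a 3.4-fold lower number from compound 1 to compound 4 (0.53 log units; beyond the scatter), so the place of the halogen on the phenyl ring can matter. Against the bare phenyl, the same bromo gives a 2.0-fold lower number from compound 2 to compound 4 (0.30 log units; within the scatter), whereas 2-bromophenyl gave a 2.1-fold higher number from compound 2 to compound 3 (0.32 log units; beyond the scatter), so a bromo is tolerated at one place and costs a modest step at the other. Nothing shown accounts for these differences.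

The halogen and its place are not separated, and 3-chlorophenyl would settle that. On these data alone, whether an amine, a carboxylic acid or a methoxy group on the phenyl ring keeps the number of compound 4 also stays open.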